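The compounds below may be only part of what the source reports. "The series", "measured", "known", "first", "only" and "open" are said of these compounds alone.

Measured compounds in a functional assay on CWR22R cells (Homo sapiens) for inhibition, with a stated time of 120 h, tested at 10 uM; a lower number here means less inhibition, a higher number more inhibition at the concentration tested (going by the name of the read-out):
compound 1 `Cc1n[nH]c2ccc(-c3nc4cnc(N5CCC(C)CC5)cn4c3Nc3ccc(Cl)cc3)cc12` — 12.6%
compound 2 `Cc1n[nH]c2ccc(-c3nc4cnc(N5CCN(C)CC5)cn4c3Nc3ccc(Br)cc3)cc12` — 11.7%
compound 3 `COc1ccc(Nc2c(-c3ccc4[nH]nc(C)c4c3)nc3cnc(N4CCN(C)CC4)cn23)cc1` — 0%

Compound 2 stands second highest of the three. Compound 1 lies within the scatter of it, whereas compound 3 lies beyond the scatter below it. The step under review leads from compound 2 to compound 4 `COc1ccc(Nc2c(-c3ccc4[nH]nc(C)c4c3)nc3cnc(N4CCN(C)CC4)cn23)cc1OC` and is 3,4-dimethoxyphenyl in place of 4-bromophenyl on a nitrogen on an aromatic ring. For the measured compounds named here, one measured step bears on it: a number 11.7 percentage points lower from compound 2 to compound 3 (beyond the scatter), where a single methoxy entered for the bromo. Compound 4 carries that same exchange together with a second methoxy, so in this assay a downward step of roughly that size is expected, with the reading most likely falling near the floor, as for compound 3. Compound 4 is therefore estimated at 1% (range 0% to 12%), an expected step of a number 10.7 percentage points lower from compound 2 to compound 4 (beyond the scatter).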

Compound 4, a percentage reported as inhibition, at one concentration (the size of the read-out at that concentration, not a potency): 0%
The estimate for compound 4 lay 1 percentage points above the measured number; the measured number falls inside the stated range.
By their numbers in this assay, from the lowest: compounds 3 and 4 (each within the scatter of the next); then compounds 2 and 1 (each within the scatter of the next).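

In this assay the 3,4-dimethoxyphenyl group gives a number 11.7 percentage points lower from compound 2 to compound 4 (beyond the scatter) and the added methoxy gives no change at the digits printed from compound 3 to compound 4 (within the scatter); any effect of the second methoxy cannot be read, since compound 3 already stands at 0% and a further fall could not show in this read-out. No measurement here accounts for the loss seen with either methoxy-bearing compound. Still open, going by these compounds, is whether a fluoro, a trifluoromethyl or a nitrile in place of the bromo would keep the reading of compound 2 at 11.7% or lose it.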